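Hydroxy to methoxy on compound 2

The source may hold more compounds than are shown below. What is called first, only, known or untested is meant among the compounds shown, and "the series" means these compounds.

Working notes on the series begin with compound 1 `COc1cc(/C=C2\Cc3c(cc(OC)c(OC)c3OC)C2=O)cc(OC)c1OC`, which in a functional assay on A549 cells (Homo sapiens) for antiproliferative activity, read by MTT assay, with a stated time of 48 h (on this read-out higher numbers stand for weaker inhibition of growth and lower numbers for stronger inhibition of growth), gives 2790 nM.

Compound 2 `COc1cc2c(cc1O)C(=O)/C(=C/c1cc(OC)c(OC)c(OC)c1)C2` has no number in this assay, only the limit > 10000 nM.

Compound 3 `COc1cc2c(cc1OC)C(=O)/C(=C/c1cc(OC)c(OC)c(OC)c1)C2` departs from compound 2 at a single place: methyl in place of hydrogen on an oxygen on an aromatic ring. This is methyl in place of hydrogen on an oxygen on an aromatic ring, or hydroxy to methoxy.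

Within the data shown here, no measured pair isolates this change, so the expectation rests on little. The expected step of an at least 2.0-fold lower number from compound 2 to compound 3 (0.30 log units; that floor lies within the scatter) points towards stronger inhibition of growth. Its size stays loose, as the starting point is a limit. Among the measured compounds shown here, the only numerical anchor is compound 1 at 2790 nM.

Compound 3 is estimated at 5000 nM, with an expected range of 1500 nM to 15000 nM.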

Compound 3, concentration for 50% growth inhibition: > 10000 nM
Compound 3 was reported as a limit; the forecaster's own chance of this, stated with the estimate: 25%; at least 2.0-fold (0.30 log units) between middle value and limit.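

Hydrogen in place of methoxy on an aromatic carbon gives an at least 3.5-fold higher number from compound 1 to compound 3 (0.55 log units; beyond the scatter) in this assay, the first readable step in the series, and it runs towards weaker inhibition of growth. Methyl in place of hydrogen on the oxygen does not bring the series back into the measurable range: compound 3 gives > 10000 nM, which is a limit of the assay. The step from hydroxy to methoxy cannot be read, because both of its ends are limits: the limit of > 10000 nM in this assay, at which 2 of the 3 values shown sit.

On these data alone, how far compound 3 lies from compound 1 stays open, as does whether hydroxy and methoxy differ at all on this oxygen. The compounds shown also do not tell what an amine, a fluorine or a longer chain such as ethoxy would give on the aromatic carbon where compound 1 carries methoxy.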